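The source may hold more compounds than are shown below. What is called first, only, known or untested is meant among the compounds shown, and "the series" means these compounds.

In a functional assay on MCF7 cells (Homo sapiens) for inhibition, read by MTT assay, with a stated time of 72 h (a lower number here means a stronger inhibitor, a higher number a weaker inhibitor), compound 3 `C=CCSc1nc2nc(C)cc(Nc3cc(-c4ccccc4)[nH]n3)n2n1` gives > 50000 nM, which is a limit of the assay and not a number. Its true position is therefore unknown, and any step that starts from it has only one firm end.

Two relatives have real numbers. Compound 1 `Cc1cc(Nc2cc(-c3ccccc3)[nH]n2)n2nc(SCCc3ccccc3)nc2n1` gives 2700 nM. Compound 2 `Cc1cc(Nc2cc(-c3ccccc3)[nH]n2)n2nc(SCc3ccc(Br)cc3)nc2n1` gives 2720 nM. The change between them, a 1.0-fold higher number from compound 1 to compound 2 (0.00 log units; within the scatter), lies within the scatter, so swapping benzyl for 4-bromophenyl made no visible difference.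

Compound 4 `Cc1ccc(CSc2nc3nc(C)cc(Nc4cc(-c5ccccc5)[nH]n4)n3n2)cc1` departs from compound 3 as follows: 4-methylphenyl in place of vinyl on a saturated chain carbon bound to a sulfur. In words, 4-methylphenyl stands in place of vinyl on a saturated chain carbon bound to a sulfur.

Among the compounds with values here, two measured steps bear on this, and both run the opposite way, with vinyl entering where a ring group stood. These are an at least 18-fold higher number from compound 1 to compound 3 (1.26 log units; beyond the scatter) and an at least 18-fold higher number from compound 2 to compound 3 (1.26 log units; beyond the scatter), both large and beyond the scatter. Reversing that swap should therefore bring a large fall in the number, meaning a stronger inhibitor. The expected change is an at least 15-fold lower number from compound 3 to compound 4 (1.19 log units; beyond the scatter), and its true size depends on where compound 3 really lies.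

The estimate for compound 4 is 3200 nM, with an expected range of 1300 nM to 8000 nM.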

Compound 4, half-maximal inhibitory concentration: 7290 nM
Estimate against measurement, compound 4: 2.3-fold (0.36 log units) below; the range from low to high includes it.
By their numbers in this assay, from the lowest: compounds 1 and 2 (each within the scatter of the next); then compound 4. At a limit, above all of these: compound 3.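

Compound 3 remains a limit and not a number, and any step from it has only one firm end: the limit of > 50000 nM in this assay, at which 1 of the 4 values shown sits.

Even so, in this assay the step of an at least 6.8-fold lower number from compound 3 to compound 4 (0.83 log units; beyond the scatter) shows that a third ring-bearing side chain, after those of compound 1 and compound 2, gives a stronger inhibitor than the allyl group does. The new result also shows that these ring-bearing side chains are not fully interchangeable, even though compound 1 and compound 2 could not be told apart. Methyl in place of bromo on an aromatic carbon gives a 2.7-fold higher number from compound 2 to compound 4 (0.43 log units; beyond the scatter) and 4-methylphenyl in place of benzyl gives a 2.7-fold higher number from compound 1 to compound 4 (0.43 log units; beyond the scatter) in the same direction, each modest but beyond the scatter.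

The compounds shown leave open whether an amine or a carboxylic acid in place of the methyl of the 4-methylphenyl group would move the number further, in either direction. They also leave open whether the limit reached by compound 3 reflects the double bond or the missing ring, a question that a propyl chain in place of the allyl group would address.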